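Swapping Sulfur for Oxygen on a Flat Series

This account rests on a few compounds, and the source may have more. Where it says the series, first, only, none or still open, it means among the compounds named here.

Measured so far in a functional assay on SF-268 cells (Homo sapiens) for cytotoxicity, read by MTT assay, with a stated time of 3 days; on this read-out higher numbers stand for weaker inhibition and lower numbers for stronger inhibition:
- compound 1 `N#Cc1c(NN)nc(SCc2nc3ccccc3[nH]2)nc1-c1ccccc1`: 2.77 nM
- compound 2 `N#Cc1c(Nc2nccs2)nc(SCc2nc3ccccc3[nH]2)nc1-c1ccccc1`: 2.55 nM
- compound 3 `N#Cc1c(NC(N)=S)nc(SCc2nc3ccccc3[nH]2)nc1-c1ccccc1`: 3.37 nM

Compound 3 sits level with the other two, since a 1.2-fold higher number from compound 1 to compound 3 (0.09 log units; within the scatter) and a 1.3-fold higher number from compound 2 to compound 3 (0.12 log units; within the scatter) are both within the scatter of repeated measurements. The next candidate is compound 4 `N#Cc1c(NC(N)=O)nc(SCc2nc3ccccc3[nH]2)nc1-c1ccccc1`, which keeps the shared core and differs at one place: a group of 3 heavy atoms (1 carbon, 1 nitrogen, 1 oxygen; no ring) in place of a group of 3 heavy atoms (1 carbon, 1 nitrogen, 1 sulfur; no ring), on a nitrogen on an aromatic ring. Carbamoyl enters on a nitrogen on an aromatic ring, where the sulfur-containing group stood.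

All three measured steps changed this same place, and the third, a 1.1-fold lower number from compound 1 to compound 2 (0.04 log units; within the scatter), was also within the scatter. These three compounds therefore show no sensitivity to the group there, and none goes against that. Among the compounds with values here, still, no measured pair tests oxygen against sulfur directly. So no step beyond the scatter is expected in this assay, and no direction can be favoured with confidence.

The estimated change is a 1.1-fold lower number from compound 3 to compound 4 (0.05 log units; within the scatter). For compound 4, the expected value is 3 nM, with an estimated range of 1.5 nM to 6 nM.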

Compound 4, half-maximal inhibitory concentration: 3.37 nM
Compound 4: middle estimate off by 1.1-fold (0.05 log units), on the low side; measured number inside the range.
By their numbers in this assay, from the lowest: compounds 2, 1, 3 and 4 (each within the scatter of the next).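

The direct comparison of oxygen with sulfur is now available: in this assay, carbamoyl on the nitrogen on an aromatic ring gives no change at the digits printed from compound 3 to compound 4 (within the scatter), so exchanging this single atom leaves the printed number unchanged. The new group also stays level with the two other groups, with a 1.3-fold higher number from compound 2 to compound 4 (0.12 log units; within the scatter) and a 1.2-fold higher number from compound 1 to compound 4 (0.09 log units; within the scatter), so compounds 1 to 4 all remain within the scatter of one another, whether or not the group carries a ring. Nothing measured here explains this flat behaviour.

Going by these compounds, whether the flatness would extend to a carboxylic acid, an acetyl group or a long alkyl chain on this nitrogen remains open. The shared core is also constant in these compounds, so they say nothing about changes elsewhere in the molecule.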